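Swapping fluoro for nitro on an oxime amide core

The source may report more compounds than this note shows. Statements on the series, on what has been measured and on what is new or still open speak of the compounds shown alone.

Compound 1 `N#C/C(=N\O)C(=O)Nc1ccc(F)cc1` is one of two cyano-oxime amides measured in a physicochemical assay for acid dissociation, using potentiometric titration. In that assay compound 1 gives 5.01, the higher of the two numbers, although its gap to compound 2 `N#C/C(=N\O)C(=O)Nc1cc(F)cc(F)c1`, which gives 4.81, falls within the scatter of the measurement, so the two cannot be told apart. For the measured compounds named here, no step between measured compounds connects compound 1 to anything else in the set.

Compound 3 `N#C/C(=N\O)C(=O)Nc1ccc([N+](=O)[O-])cc1` has not yet been measured. It differs from compound 1 in one place: nitro in place of fluoro on an aromatic carbon. Going by the values given here, with only the two values of compound 1 and compound 2 available, and no measured step to lean on, the expectation rests on the change itself.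

Compound 3 is expected to show a moderate step down from compound 1, placed at a number 0.51 log units lower from compound 1 to compound 3 (beyond the scatter), somewhat beyond the scatter rather than within it. In this assay compound 3 is therefore estimated to give 4.5, with a plausible range from 4.15 to 4.85, the measured value itself remaining to be seen.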

Compound 3, acid dissociation constant: 4.61
Estimate against measurement, compound 3: 0.11 log units below; measured number inside the range.
By their numbers in this assay, from the lowest: compounds 3, 2 and 1 (each within the scatter of the next, the first and the last beyond it).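

In this assay, for the compounds shown here, nitro in place of fluoro on an aromatic carbon gives the first step in this set that can be read from a change in one place: a number 0.40 log units lower from compound 1 to compound 3 (beyond the scatter). It shows that this position, on the six-membered aromatic ring and para to a group of 8 heavy atoms, is not indifferent to the group it carries, since one exchange there moves the number beyond the scatter, something compound 1 and compound 2 alone could not show. The data offer no measured account of why the number moves in this direction or by this amount.

Going by these compounds, what remains open is how far the number follows the group at this position, for instance with an amine, a methoxy group or trifluoromethyl in place of fluoro, and whether such groups would fall on the same side of compound 1 as compound 3 does. Also open, on these data alone, is whether nitro in place of fluoro would give a similar step at another place on the ring or on a core carrying a second fluoro.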